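Metabolic stability notes: triazolylamino to tetrazolylmethyl swap

A few compounds are considered here, and "the series" means these few. Any claim that something is new, unique, unknown or untested is made for them only; others in the source may bear on it.

Measured compounds:
compound 1, `CC(C)C(Nc1nnc[nH]1)c1ccc(-c2ccc3cccc(F)c3c2)[nH]c1=O`, 1.29 h
compound 2, `CC(C)C(Nc1nccs1)c1ccc(-c2ccc3cccc(F)c3c2)[nH]c1=O`, 0.07 h

In an ADME assay on microsomes from liver (Rattus norvegicus) for metabolic stability (on this read-out lower numbers stand for a shorter-lived compound and higher numbers for a longer-lived compound), compound 1 stands highest of the two numbers; the nearest is compound 2, reached by an 18-fold lower number from compound 1 to compound 2 (1.27 log units; beyond the scatter), a large step with the change of 1,3-thiazol-2-yl in place of 4H-1,2,4-triazol-3-yl on an amine nitrogen.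

Compound 3, `CC(C)C(Cc1nnn[nH]1)c1ccc(-c2ccc3cccc(F)c3c2)[nH]c1=O`, is not yet measured in this assay. It differs from compound 1 by (1H-tetrazol-5-yl)methyl in place of (4H-1,2,4-triazol-3-yl)amino on a saturated chain carbon bound to an aromatic carbon and a saturated chain carbon. For the measured compounds named here, the only measured step, that from compound 1 to compound 2, concerns a different change and bears on this one only loosely: it shows that altering the group on this carbon can move this assay by a large amount, but gives no direct guide for the present change. With the amine nitrogen leaving altogether, a lower number than compound 1 is expected, of modest size, a 1.8-fold lower number from compound 1 to compound 3 (0.27 log units; within the scatter), not clearly beyond the scatter. Compound 3 is therefore estimated at 0.7 h, in the range 0.15 h to 2.5 h.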

Compound 3, half-life: 2.08 h
For compound 3 the middle estimate is 3.0-fold (0.47 log units) below the measured one; measured number inside the range.
By their numbers in this assay, from the lowest: compound 2; then compounds 1 and 3 (each within the scatter of the next).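

In this assay, (1H-tetrazol-5-yl)methyl in place of (4H-1,2,4-triazol-3-yl)amino gives a 1.6-fold higher number from compound 1 to compound 3 (0.21 log units; within the scatter), so on this saturated chain carbon the amine nitrogen can be lost with no change beyond the scatter. The same group in place of (1,3-thiazol-2-yl)amino gives a 30-fold higher number from compound 2 to compound 3 (1.47 log units; beyond the scatter), which leaves compound 2 as the only one of the three clearly apart from the others. Nothing at hand accounts for either step.

Still open, from the compounds shown here alone, is whether the low number of compound 2 goes with its thiazole ring or with its amine nitrogen; a (1,3-thiazol-2-yl)methyl group on this carbon would separate the two. Also open, going by these compounds, is how a carboxylic acid at this place, or a longer chain carrying the tetrazole, would read in this assay.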